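Aminoethyl-piperazine capping: isothiocyanate to acrylamide

The source may hold more compounds than are shown below. What is called first, only, known or untested is meant among the compounds shown, and "the series" means these compounds.

Measured compounds:
- compound 1 `Cc1ccc(-c2nnc(-c3ccc(CN4CCN(C)CC4)c(C(F)(F)F)c3)o2)cc1Nc1nccc(-c2cccnc2)n1`: 50 nM
- compound 2 `Cc1ccc(-c2nnc(-c3ccc(CN4CCN(CCN)CC4)c(C(F)(F)F)c3)o2)cc1Nc1nccc(-c2cccnc2)n1`: 20 nM
- compound 3 `Cc1ccc(-c2nnc(-c3ccc(CN4CCN(CCN=C=S)CC4)c(C(F)(F)F)c3)o2)cc1Nc1nccc(-c2cccnc2)n1`: 70 nM

In a functional assay on HL-60 cells (Homo sapiens) for inhibition, read by MTT assay, with a stated time of 72 h (a lower number here means a stronger inhibitor, a higher number a weaker inhibitor), compound 3 gives the highest of the three numbers. Its gap to compound 1 is within the scatter, seen in a 1.4-fold higher number from compound 1 to compound 3 (0.15 log units; within the scatter); its gap to compound 2 is beyond it, seen in a 3.5-fold higher number from compound 2 to compound 3 (0.54 log units; beyond the scatter). Compound 2 itself sits below compound 1 by a 2.5-fold lower number from compound 1 to compound 2 (0.40 log units; beyond the scatter).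

Compound 4 `C=CC(=O)NCCN1CCN(Cc2ccc(-c3nnc(-c4ccc(C)c(Nc5nccc(-c6cccnc6)n5)c4)o3)cc2C(F)(F)F)CC1` differs from compound 3 by a group of 5 heavy atoms (3 carbon, 1 nitrogen, 1 oxygen; no ring) in place of a group of 3 heavy atoms (1 carbon, 1 nitrogen, 1 sulfur; no ring), on a saturated chain carbon, two bonds along the chain from an amine nitrogen in a ring. The step that bears on it is a 3.5-fold higher number from compound 2 to compound 3 (0.54 log units; beyond the scatter), where the free nitrogen of compound 2 was replaced at the same place and the number rose modestly; the change to compound 4 again replaces the terminal group of that chain, this time with a group carrying one hydrogen-bond donor, so the number is expected to fall between compound 2 and compound 3 rather than beyond either. A modest improvement relative to compound 3 is therefore expected, a 1.6-fold lower number from compound 3 to compound 4 (0.19 log units; within the scatter), with the uncertainty spanning both neighbours. For compound 4 the estimate in this assay is 45 nM, with a range from 20 nM to 110 nM.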

Compound 4, half-maximal inhibitory concentration: 2660 nM
Compound 4: middle estimate off by 59-fold (1.77 log units), on the low side, outside the stated range (above it).
By their numbers in this assay, from the lowest: compound 2; then compounds 1 and 3 (each within the scatter of the next); then compound 4.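

Until now this position had held all three terminal groups close together, but the (vinylcarbonyl)amino group breaks that range in this assay, with a 38-fold higher number from compound 3 to compound 4 (1.58 log units; beyond the scatter). The loss is just as clear against the other two compounds, with a 130-fold higher number from compound 2 to compound 4 (2.12 log units; beyond the scatter) and a 53-fold higher number from compound 1 to compound 4 (1.73 log units; beyond the scatter), so compound 4 is the weakest of the four and this place on the chain is not indifferent to what caps it. Capping the free amine of compound 2 as this amide costs more than any other change in the set, and no measurement shown gives a reason for the loss.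

The compounds shown do not separate the part played by the vinyl group from that of the amide itself, which a saturated propanoyl amide or an acetyl amide would address. From the compounds shown here alone, whether a longer chain carrying the same (vinylcarbonyl)amino group behaves like compound 4 also stays open.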